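This account rests on a few compounds, and the source may have more. Where it says the series, first, only, none or still open, it means among the compounds named here.

Three compounds have been measured so far:

compound 1, `Nc1scc(CN2CCN(c3ccc(Cl)c(C(F)(F)F)c3)CC2)c1C(=O)c1ccc(Cl)cc1`, 0%
compound 2, `Nc1scc(CN2CCN(C3CCCCCC3)CC2)c1C(=O)c1ccc(Cl)cc1`, 0%
compound 3, `Nc1scc(CN2CCN(c3cccc(F)c3)CC2)c1C(=O)c1ccc(Cl)cc1`, 1%

All three share the same core and differ only in the group carried on an amine nitrogen in a ring. In an assay on CHO cells for displacement of a labelled ligand from adenosine receptor A1 (Homo sapiens), read by scintillation counting, with a stated time of 120 min, tested at 10 uM (a lower number here means less inhibition, a higher number more inhibition at the concentration tested (going by the name of the read-out)), compound 1 gives 0%, compound 2 gives 0% and compound 3 gives 1%. Compound 3 holds the highest of the three numbers, but its gap to compound 1 and to compound 2 lies within the scatter, so the three are indistinguishable. The steps are no change at the digits printed from compound 1 to compound 2 (within the scatter), a number 1 percentage points higher from compound 1 to compound 3 (within the scatter) and a number 1 percentage points higher from compound 2 to compound 3 (within the scatter): exchanging a substituted phenyl for a cycloheptyl or for a 3-fluorophenyl on that ring nitrogen made no difference at all.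

Compound 4, `Nc1scc(CN2CCN(c3cccc(F)c3F)CC2)c1C(=O)c1ccc(Cl)cc1`, differs from compound 3 by fluoro in place of hydrogen on an aromatic carbon, that is, 3-fluorophenyl becomes 2,3-difluorophenyl. Among the compounds with values here, none of the measured steps tests exactly this change, but every step seen, however large the swap, left the read-out unchanged. A single added fluoro is therefore expected to give a number 1 percentage points higher from compound 3 to compound 4 (within the scatter), no step beyond the scatter. Compound 4 is estimated at 2%, with a range from 0% to 12%.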

Compound 4, a percentage reported as inhibition, at one concentration (the size of the read-out at that concentration, not a potency): 0%
The estimate for compound 4 lay 2 percentage points above the measured number; the measured number falls inside the stated range.
By their numbers in this assay, from the lowest: compounds 1, 2, 4 and 3 (each within the scatter of the next).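

In this assay, within the data shown here, placing a fluoro on an aromatic carbon, ortho to a fluoro group and ortho to a large group, gives a number 1 percentage points lower from compound 3 to compound 4 (within the scatter) and so offers the first direct look at this position of the aromatic ring: 3-fluorophenyl and 2,3-difluorophenyl cannot be told apart here. The new group also fits the flat picture seen on the ring nitrogen, with no change at the digits printed from compound 2 to compound 4 (within the scatter) and no change at the digits printed from compound 1 to compound 4 (within the scatter), so none of the four compounds stands out from the others. No measured information is available to explain this result.

Still open, going by these compounds, is whether any group on that ring nitrogen can move the read-out beyond the scatter, for example a phenyl ring carrying an amine or a carboxylic acid, or a longer chain such as a phenylpropyl group. Also open, on these data alone, is whether a change elsewhere on the shared core, such as an amide in place of the ketone, would matter more than these swaps on the ring nitrogen.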